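Swapping pyridin-4-yl for thiophen-2-yl in compound 1

This account rests on a few compounds, and the source may have more. Where it says the series, first, only, none or still open, it means among the compounds named here.

Compound 1 `CCN(c1ccc(C#N)c(Cl)c1)c1cc(-c2ccncc2)ccc1C`: 3580 nM
Compound 2 `N#Cc1ccc(N2CCc3cc(-c4cccnc4)ccc32)cc1C(F)(F)F`: "not determined" (no result reported)
Compound 3 `CCN(c1cccc(-n2ccnc2)c1)c1ccc(C#N)c(C(F)(F)F)c1`: > 30000 nM

In a functional assay on PC-3 cells (Homo sapiens) for antiproliferative activity, read by CCK-8 assay, with a stated time of 6 days (a lower number here means a stronger inhibitor, a higher number a weaker inhibitor), compound 1 at 3580 nM holds the only actual number among these compounds. For compound 3 the entry > 30000 nM is a limit of the assay and not a number. Compound 4 `CCN(c1ccc(C#N)c(Cl)c1)c1cc(-c2cccs2)ccc1C` is not yet measured. Its difference from compound 1 is thiophen-2-yl in place of pyridin-4-yl on an aromatic carbon with thiophen-2-yl in place of pyridin-4-yl on an aromatic carbon. Among the compounds with values here, no measured pair of compounds tests this swap, so the expectation is cautious. The shift expected in this assay stays within the usual scatter, with a 1.3-fold higher number from compound 1 to compound 4 (0.10 log units; within the scatter) as the estimate. For compound 4 the estimated value is 4500 nM with an expected range from 1500 nM to 14000 nM in this assay.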

Compound 4, half-maximal inhibitory concentration: > 30000 nM
Compound 4 gave a limit, no number; the forecaster's own chance of this, stated with the estimate: 12%; middle value at least 6.6-fold (0.82 log units) away from the limit.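

In this assay, this position does not accept every aromatic ring: thiophen-2-yl in place of pyridin-4-yl gives an at least 8.3-fold higher number from compound 1 to compound 4 (0.92 log units; beyond the scatter). The two rings have matching counts of hetero atoms and hydrogen-bond acceptors, so those counts alone do not predict this result. Compound 4 gives a limit and not a number, so the full size of the step stays unknown: the limit of > 30000 nM in this assay, at which 2 of the 4 values shown sit.

From the compounds shown here alone, it remains open which feature of pyridin-4-yl matters. A plain phenyl ring, or a pyridine ring carrying an amine, could show whether activity at this position can be kept or improved.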